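Swapping 4-hydroxyphenyl for isopropyl

The source may hold more compounds than are shown below. What is called first, only, known or untested is meant among the compounds shown, and "the series" means these compounds.

compound 1 `CC/C=C\C[C@H]1C(=O)C=C[C@H]1CC(=O)Oc1ccc(O)cc1` gives 23000 nM
compound 2 `CC/C=C\C[C@H]1C(=O)C=C[C@H]1CC(=O)Oc1ccccc1OC` gives 32000 nM

In a functional assay on RAW264.7 cells (Mus musculus) for inhibition, read by ELISA, with a stated time of 24 h (a lower number here means that less compound is needed, a higher number that more compound is needed for the effect), compound 1 gives 23000 nM as its value and compound 2 gives 32000 nM as its value, so the two stand within the usual scatter of each other. Compound 3 `CC/C=C\C[C@H]1C(=O)C=C[C@H]1CC(=O)OC(C)C` differs from compound 1 by isopropyl in place of 4-hydroxyphenyl on an oxygen next to a carbonyl group and so carries isopropyl in place of 4-hydroxyphenyl on an oxygen next to a carbonyl group. Among the compounds with values here, no measured pair shows what such a swap does, so the expected result in this assay is a 1.3-fold higher number from compound 1 to compound 3 (0.12 log units; within the scatter) and no shift beyond the scatter. Compound 3 is estimated at 30000 nM with an expected range from 10000 nM to 85000 nM in this measurement.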

Compound 3, half-maximal effective concentration: 20000 nM
Beside the measured number, compound 3's estimate is 1.5-fold (0.18 log units) above it; measured number inside the range.
By their numbers in this assay, from the lowest: compounds 3, 1 and 2 (each within the scatter of the next).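

In this assay isopropyl in place of 4-hydroxyphenyl on an oxygen next to a carbonyl group gives a 1.2-fold lower number from compound 1 to compound 3 (0.06 log units; within the scatter) so an aromatic ring is not required here to keep the number within the scatter. Compound 1 and compound 2 both carry such a ring at this place, so they could not show this. Nothing measured here explains why the change leaves the number within the scatter.

Still open, from the compounds shown here alone, is whether any group at this place can move the number beyond the scatter. A longer chain, an amine or a carboxylic acid could test that.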